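The source may report more compounds than this note shows. Statements on the series, on what has been measured and on what is new or still open speak of the compounds shown alone.

Measured so far:
- compound 1 `O=C(NCc1ccc(S(=O)(=O)N2CCCCC2)cc1)c1cc2cnccc2s1`: 1600 nM
- compound 2 `O=C(NCc1ccc(S(=O)(=O)c2ccccc2C(F)(F)F)cc1)c1cc2cnccc2[nH]1`: 25 nM

Both values come from a functional assay on A2780 cells (Homo sapiens) for inhibition, read by sulforhodamine B assay, with a stated time of 72 h; on this read-out higher numbers stand for weaker inhibition and lower numbers for stronger inhibition. Of the two, compound 1 at 1600 nM has the higher number, and compound 2 stands at 25 nM. The gap between these two values lies beyond the scatter. Compound 3 `O=C(NCc1ccc(S(=O)(=O)N2CCCCC2)cc1)c1cc2ccncc2[nH]1` is not yet measured. It keeps the piperidine sulfonyl side of compound 1 and changes the group on the carbonyl carbon: a group of 9 heavy atoms (7 carbon, 2 nitrogen; one five-membered aromatic ring with 1 hetero atom, one six-membered aromatic ring with 1 hetero atom) in place of a group of 9 heavy atoms (7 carbon, 1 nitrogen, 1 sulfur; one five-membered aromatic ring with 1 hetero atom, one six-membered aromatic ring with 1 hetero atom), on a carbonyl carbon. Among the compounds with values here, no measured pair isolates this change. Compound 2 at 25 nM differs from compound 1 in more than one place, so it gives only a weak hint towards lower numbers. In this assay, the expected change is small, a 1.8-fold lower number from compound 1 to compound 3 (0.25 log units; within the scatter), and probably not beyond the scatter. For compound 3 the estimated value is 900 nM, with an expected range of 150 nM to 5000 nM.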

Compound 3, half-maximal inhibitory concentration: 1700 nM
Compound 3: the middle estimate sits 1.9-fold (0.28 log units) below what was measured; the range from low to high includes it.
By their numbers in this assay, from the lowest: compound 2; then compounds 1 and 3 (each within the scatter of the next).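

With the piperidine sulfonyl side held fixed, exchanging the group on the carbonyl carbon gives a 1.1-fold higher number from compound 1 to compound 3 (0.03 log units; within the scatter) in this assay. At this place, then, the sulfur-containing group with 0 hydrogen-bond donors and 2 hydrogen-bond acceptors and the group with 2 nitrogens, 1 hydrogen-bond donor and 1 hydrogen-bond acceptor cannot be told apart on this read-out, at least with the piperidine sulfonyl side present. No measurement at hand bears on the reason for this result.

Compound 2 differs from compound 1 and from compound 3 in more than one place, so the share of the sulfonyl side in its value stays unresolved. Also open, going by these compounds, is how a morpholine in place of the piperidine, or a simple phenyl on the carbonyl carbon, would read in this assay.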